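Adding a phenyl ring to compound 1

The source may report more compounds than this note shows. Statements on the series, on what has been measured and on what is new or still open speak of the compounds shown alone.

Compound 1 `Cn1c(CN2C[C@@H]3C(COc4ccccc4)[C@@H]3C2)nc2ccccc21` gives 24 nM in an in vitro assay on HEK293 cells with metabotropic glutamate receptor 2 (Rattus norvegicus) as the target, read by FLIPR, in the presence of a further agent that is not named here (on this read-out lower numbers stand for an effect already at smaller amounts and higher numbers for an effect only at larger amounts of compound), the lowest of the two numbers measured; compound 2 `c1ccc(OCC2[C@H]3CN(Cc4nc5ccccc5n4C4CC4)C[C@@H]23)cc1` gives 3020 nM in this assay, and the step of a 130-fold higher number from compound 1 to compound 2 (2.10 log units; beyond the scatter) came from a change on an aromatic nitrogen. Compound 3 `Cn1c(CN2C[C@@H]3C(COc4cccc(-c5ccccc5)c4)[C@@H]3C2)nc2ccccc21` differs from compound 1 elsewhere: phenyl in place of hydrogen on an aromatic carbon, meta to a large group. Among the measured compounds shown here, no measured step touches this part of the shared core, so the only measured step says nothing about its size. A modest step of a 1.7-fold higher number from compound 1 to compound 3 (0.22 log units; within the scatter) is therefore expected, and compound 3 is estimated at 40 nM, between 8 nM and 200 nM.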

Compound 3, half-maximal effective concentration: 113 nM
Compound 3: the middle estimate sits 2.8-fold (0.45 log units) below what was measured, within the range that was stated.
By their numbers in this assay, from the lowest: compound 1; then compound 3; then compound 2.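

Phenyl in place of hydrogen on this aromatic carbon, meta to a large group, is the first change shown away from the aromatic nitrogen, and in this assay it gives a 4.7-fold higher number from compound 1 to compound 3 (0.67 log units; beyond the scatter) as a modest step. This part of compound 1 therefore responds to a change, though with a smaller step than the one on the aromatic nitrogen, a 130-fold higher number from compound 1 to compound 2 (2.10 log units; beyond the scatter) in the same assay. Going by these compounds, whether an amine or a methoxy group on this same carbon would give a smaller or larger step stays open. No data shown here bear on the cause of this rise.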